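The compounds below may be only part of what the source reports. "The series", "measured", "known", "first", "only" and "open" are said of these compounds alone.

Measured so far in an ADME assay on HCT-116 cells (Homo sapiens) for cytotoxicity, read by MTT assay; a lower number here means that less compound is tolerated, a higher number that more compound is tolerated:

Compound 1 `Cc1nc(-c2cccnc2)sc1-c1nnc(-c2ccc([N+](=O)[O-])cc2)o1` gives > 100 ug/mL, a limit of the assay and not a number.
Compound 2 `Cc1ccc(-c2nnc(-c3sc(-c4cccnc4)nc3C)o2)cc1` gives > 100 ug/mL, likewise a limit.
Compound 3 `Cc1ccccc1-c1nnc(-c2sc(-c3cccnc3)nc2C)o1` gives > 100 ug/mL, likewise a limit.

Compound 2 and compound 1 differ by nitro in place of methyl on an aromatic carbon; the step that the two limits leave unreadable from compound 2 to compound 1 cannot be read, because the limit of > 100 ug/mL in this assay, at which 3 of the 3 values shown sit, holds both values. The two cores of compound 2 and compound 3 differ by 2-methylphenyl in place of 4-methylphenyl on an aromatic carbon, and the step that the two limits leave unreadable from compound 2 to compound 3 is unreadable for the same reason.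

Compound 4 `Cc1nc(-c2cccnc2)sc1-c1nnc(-c2ccccc2[N+](=O)[O-])o1`, not yet measured, differs from compound 3 by nitro in place of methyl on an aromatic carbon. This is the same kind of change as that from compound 2 to compound 1, but the place differs: in compound 4 the nitro sits ortho to a large group, whereas in compound 1 it sits para to a large group. Within the data shown here, since every value shown rests at the limit of > 100 ug/mL in this assay, at which 3 of the 3 values shown sit, and no step has been readable, compound 4 is expected to stay near that limit as well, with a step that the limit leaves unreadable from compound 3 to compound 4 as the expected step. The estimate for compound 4 in this assay is 150 ug/mL, within 60 ug/mL to 400 ug/mL.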

Compound 4, half-maximal cytotoxic concentration: > 100 ug/mL
Compound 4 ended at the assay's limit; the forecaster's own chance of this, stated with the estimate: 85%; the middle value does not contradict the limit.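

In this assay compound 4 gives > 100 ug/mL, a limit of the assay and not a number. No step can be read from compound 3 to compound 4, nor any other step in the series: the limit of > 100 ug/mL in this assay, at which 4 of the 4 values shown sit.

The compounds shown leave open whether nitro in place of methyl changes the tolerated concentration at all.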